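The source may hold more compounds than are shown below. What is called first, only, known or untested is meant among the compounds shown, and "the series" means these compounds.

Three compounds sharing one core, differing only in the amine at the end of the chain, have been tested in a functional assay on MCF7 cells (Homo sapiens) for antiproliferative activity; on this read-out higher numbers stand for weaker inhibition and lower numbers for stronger inhibition. Compound 1 `CCN(CC)CCCOc1ccc2cc(NC(=O)c3ccc(O)c(CC=C(C)C)c3)c(=O)oc2c1C`, with diethylamino, gives 6390 nM, and compound 2 `CC(C)=CCc1cc(C(=O)Nc2cc3ccc(OCCCN(C)C(C)C)c(C)c3oc2=O)ccc1O`, with isopropyl(methyl)amino, gives 1050 nM. As far as these compounds go, compound 3 `CC(C)=CCc1cc(C(=O)Nc2cc3ccc(OCCCNc4ccccc4)c(C)c3oc2=O)ccc1O`, with anilino, gives only a limit of the assay, > 50000 nM, so it has no measured number and its true position is unknown.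

Compound 4 `CC(C)=CCc1cc(C(=O)Nc2cc3ccc(OCCCN[C@H](C)c4ccccc4)c(C)c3oc2=O)ccc1O` changes this amine again: 1-phenylethyl in place of phenyl on an amine nitrogen. The measured steps at the same place on the chain are the best guide. Changing diethylamino to anilino gave an at least 7.8-fold higher number from compound 1 to compound 3 (0.89 log units; beyond the scatter), and changing isopropyl(methyl)amino to anilino gave an at least 47-fold higher number from compound 2 to compound 3 (1.67 log units; beyond the scatter). Among the two saturated amines, the difference was smaller, at a 6.1-fold lower number from compound 1 to compound 2 (0.78 log units; beyond the scatter). In compound 4, a saturated carbon of the 1-phenylethyl group replaces the phenyl ring on the amine nitrogen, which resembles compounds 1 and 2 more closely, although a ring is retained. A clear recovery towards their values is therefore expected, but the evidence is thin and the range must stay wide. The expected change is an at least 16-fold lower number from compound 3 to compound 4 (1.22 log units; beyond the scatter). For compound 4 the estimated value is 3000 nM, with an expected range from 700 nM to 20000 nM.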

Compound 4, half-maximal inhibitory concentration: 1450 nM
The estimate for compound 4 lay 2.1-fold (0.32 log units) above the measured number; low and high end bracket the measured number.
By their numbers in this assay, from the lowest: compounds 2 and 4 (each within the scatter of the next); then compound 1. At a limit, above all of these: compound 3.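

The phenyl ring alone does not account for the loss seen with anilino: 1-phenylethyl keeps that ring on the amine nitrogen, yet this assay shows an at least 34-fold lower number from compound 3 to compound 4 (1.53 log units; beyond the scatter). The true size of this step stays unknown, since compound 3 is held only at a limit of the assay: the limit of > 50000 nM in this assay, at which 1 of the 4 values shown sits. Set against the saturated amines, the new group cannot be told apart from isopropyl(methyl)amino, with a 1.4-fold higher number from compound 2 to compound 4 (0.14 log units; within the scatter), while the change from diethylamino gives a 4.4-fold lower number from compound 1 to compound 4 (0.64 log units; beyond the scatter), so among the compounds shown a ring on this amine is compatible with good activity, as long as a saturated carbon rather than the ring itself sits on the nitrogen.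

As far as these compounds go, what remains open is whether this recovery needs the methyl group of 1-phenylethyl or only the saturated carbon, a question that benzylamino at the end of the same chain would help to answer. Also open, from the compounds shown here alone, is whether the mirror-image form of 1-phenylethyl, with the opposite arrangement at its stereocentre, would give a similar number in this position.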